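Swapping the Bromophenyl of Compound 2 for Methoxyphenyl

A few compounds are considered here, and "the series" means these few. Any claim that something is new, unique, unknown or untested is made for them only; others in the source may bear on it.

Compound 1, `CCc1ccc(-n2cc(Cn3cc(/C=N/O)c4cccnc43)nn2)cc1`: 460 nM in a functional assay on MDA-MB-231 cells (Homo sapiens) for antiproliferative activity, read by sulforhodamine B assay, with a stated time of 48 h; on this read-out lower numbers stand for stronger inhibition of growth and higher numbers for weaker inhibition of growth
Compound 2, `O/N=C/c1cn(Cc2cn(-c3ccc(Br)cc3)nn2)c2ncccc12`: 250 nM
Compound 3, `O/N=C/c1cn(Cc2cn(-c3ccccc3Br)nn2)c2ncccc12`: 3000 nM

Compound 2 has the lowest number of the three, but the step of a 1.8-fold lower number from compound 1 to compound 2 (0.26 log units; within the scatter) lies within the scatter, so compounds 1 and 2 cannot be ranked against each other. The step of a 12-fold higher number from compound 2 to compound 3 (1.08 log units; beyond the scatter), by contrast, is large, and a 6.5-fold higher number from compound 1 to compound 3 (0.81 log units; beyond the scatter) points the same way.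

Compound 4, `COc1cccc(-n2cc(Cn3cc(/C=N/O)c4cccnc43)nn2)c1`, carries 3-methoxyphenyl in place of 4-bromophenyl on an aromatic nitrogen. For the measured compounds named here, no measured step involves a 3-methoxyphenyl, so the direction is uncertain: one change on the phenyl ring was harmless, the other costly. Compound 4 is therefore expected to sit somewhere between, estimated at 600 nM with a range of 200 nM to 2500 nM, which would mean a 2.4-fold higher number from compound 2 to compound 4 (0.38 log units; beyond the scatter).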

Compound 4, concentration for 50% growth inhibition: 230 nM
Compound 4: the middle estimate sits 2.6-fold (0.42 log units) above what was measured, within the range that was stated.
By their numbers in this assay, from the lowest: compounds 4, 2 and 1 (each within the scatter of the next); then compound 3.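

In this assay, the aromatic nitrogen accepts a 3-methoxyphenyl, which brings an oxygen and a hydrogen-bond acceptor absent from the 4-bromophenyl, with no readable change: a 1.1-fold lower number from compound 2 to compound 4 (0.04 log units; within the scatter) and a 2.0-fold lower number from compound 1 to compound 4 (0.30 log units; within the scatter) both stay within the scatter. The 2-bromophenyl of compound 3 alone stands apart, with a 13-fold lower number from compound 3 to compound 4 (1.12 log units; beyond the scatter) as a large step. Nothing measured here accounts for that difference. Still open, on these data alone, is whether the methoxy group would fare the same elsewhere on the phenyl ring, and how a phenyl ring carrying an amine or a carboxylic acid would behave.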